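Inverting Two Ring Stereocentres from Compound 3 to Compound 4

A few compounds are considered here, and "the series" means these few. Any claim that something is new, unique, unknown or untested is made for them only; others in the source may bear on it.

Of the compounds shown here, three share a core and have been measured in a functional assay for antagonist activity at melanin-concentrating hormone receptor 1 (Homo sapiens); a higher number here means a weaker inhibitor, a lower number a stronger inhibitor. Compound 1 `NCc1ncc([C@]23CC[C@@H](N(CCN4CC[C@H](O)C4)C(=O)Nc4ccc(F)c(C(F)(F)F)c4)C2C3)s1` gives 99 nM in this assay. Compound 2 `NCc1ncc([C@]23CC[C@@H](N(CCCN4CC5CC4CN5)C(=O)Nc4ccc(F)c(C(F)(F)F)c4)C2C3)s1` gives 73 nM. Compound 3 `C[C@@H]1CN(CCCN(C(=O)Nc2cc(Cl)nc(Cl)c2)[C@H]2CC[C@@]3(c4cnc(CN)s4)C[C@@H]23)[C@@H](C)CN1` gives 117 nM, the highest number of the three, though the step from compound 1 to compound 3 and the step from compound 2 to compound 3 both lie within the scatter.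

Going by the values given here, the only measured step between single-change neighbours, a 1.4-fold lower number from compound 1 to compound 2 (0.13 log units; within the scatter), concerns a replacement of the ring at the end of the chain and is itself within the scatter.

Among the compounds with values here, compound 4 `C[C@@H]1CN[C@@H](C)CN1CCCN(C(=O)Nc1cc(Cl)nc(Cl)c1)[C@H]1CC[C@@]2(c3cnc(CN)s3)C[C@@H]12` is the next compound. the two compounds have the same atoms and bonds and differ only in configuration as drawn: 2 of 5 stereo elements differ; a stereocentre at a saturated ring carbon is drawn S in compound 3 and R in compound 4; a stereocentre at a saturated ring carbon is drawn R in compound 3 and S in compound 4 No measured step touches a change in configuration alone; the step from compound 1 to compound 2 alters atoms, not configuration, so it offers no guide to direction or size here. With nothing to anchor a direction, the expectation for compound 4 is a step of a 1.3-fold higher number from compound 3 to compound 4 (0.11 log units; within the scatter) in this assay, which is no more than a guess centred near compound 3 with a widened range. Compound 4 is therefore estimated at 150 nM in this assay, between 50 nM and 500 nM.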

Compound 4, inhibition constant: 171 nM
Compound 4: the middle estimate sits 1.1-fold (0.06 log units) below what was measured; low and high end bracket the measured number.
By their numbers in this assay, from the lowest: compounds 2, 1, 3 and 4 (each within the scatter of the next, the first and the last beyond it).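

Going by these compounds alone, the pair gives the first measured step that concerns configuration alone in this assay, since the earlier step, a 1.4-fold lower number from compound 1 to compound 2 (0.13 log units; within the scatter), altered atoms at the end of the chain: a 1.5-fold higher number from compound 3 to compound 4 (0.16 log units; within the scatter). With two stereocentres at saturated ring carbons inverted together, compound 3 and compound 4 stay within the scatter of each other, so for this pair the assay does not separate the two drawn configurations. Whatever small gap the numbers show can be set against configuration and nothing else, because no atom or bond separates the two structures: the fact that compounds 3 and 4 differ only in the configuration as drawn

The compounds shown leave open what inverting only one of the two stereocentres would do, since both change together here, and whether the same closeness would hold for the other ring carbons among the stereo elements. They also leave open whether the two configurations would stay this close with a morpholine or another amine at the end of the chain, or with a longer chain in place of the present one.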